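Swapping a Pentyl Chain for Benzyl on an Acylguanidine

This account rests on a few compounds, and the source may have more. Where it says the series, first, only, none or still open, it means among the compounds named here.

Measured so far:
Compound 1, `CCCCCNC(=O)/N=C(\N)NCCCc1sc(N)nc1C`: 4.47 nM
Compound 2, `Cc1nc(N)sc1CCCN/C(N)=N/C(=S)N[C@H](C)c1ccccc1`: 115 nM

Both compounds share the same aminothiazole-bearing core and were tested in an assay on membranes from Sf9 cells for displacement of a labelled ligand from histamine H2 receptor (Homo sapiens), read by scintillation counting, with a stated time of 60 min; a lower number here means a stronger inhibitor, a higher number a weaker inhibitor. Compound 1 gives 4.47 nM, the lowest of the two numbers. Compound 2 gives 115 nM, a considerably higher number, well beyond the usual scatter; since compound 2 differs from compound 1 in more than one place, its value shows only that it is the weaker binder of the pair, not what any single change does.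

The next compound, compound 3, `Cc1nc(N)sc1CCCN/C(N)=N/C(=O)NCc1ccccc1`, differs from compound 1 in exactly one place: phenyl in place of butyl on a saturated chain carbon bound to an amide-type nitrogen. Within the data shown here, no measured pair shows this change on its own, so its effect cannot be read from the data. A flexible chain is traded for a flat aromatic ring of roughly similar reach, and such exchanges often leave binding close to where it was, sometimes a little weaker.

The expected step from compound 1 to compound 3 in this assay is a small rise, a 2.2-fold higher number from compound 1 to compound 3 (0.35 log units; beyond the scatter), near the edge of the scatter. Compound 3 is therefore estimated at 10 nM, within a range of 3 nM to 40 nM.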

Compound 3, inhibition constant: 69.2 nM
Compound 3: middle estimate off by 6.9-fold (0.84 log units), on the low side; measured number outside the range, above it.
By their numbers in this assay, from the lowest: compound 1; then compounds 3 and 2 (each within the scatter of the next).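

In this assay, phenyl in place of butyl on a saturated chain carbon bound to an amide-type nitrogen gives a 15-fold higher number from compound 1 to compound 3 (1.19 log units; beyond the scatter), a large loss of binding from one change. Compound 1 and compound 2 differ in more than one place, so they could not show what any single group at this position does; this pair shows that the group at the end of this side chain strongly affects the result, and that pentyl and benzyl are not interchangeable here. The data offer no measurement that explains this rise, so its cause remains unknown.

A single pair cannot separate the effect of having a ring from the effect of that ring being aromatic, and a cyclohexylmethyl group on the same nitrogen would help to tell these apart. Going by these compounds, it also remains open how much the chain itself can vary, since a propyl or a hexyl chain in place of pentyl would show whether compound 1 sits near the best length or only at one point on a wider trend.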